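Changing the Ester Tail: From Compound 3 to Compound 4

The source may hold more compounds than are shown below. What is called first, only, known or untested is meant among the compounds shown, and "the series" means these compounds.

Three compounds share one core and differ only in the group on a saturated chain carbon bound to an oxygen next to a carbonyl group. In a functional assay on HEK293 cells for antagonist activity at Voltage-dependent L-type calcium channel subunit alpha-1D (Rattus norvegicus), read by FLIPR (a lower number here means a stronger inhibitor, a higher number a weaker inhibitor), compound 1 `COC(=O)C1=C(C)NC(C)=C(C(=O)OCC2CC2)C1c1cccc([N+](=O)[O-])c1` gives 21 nM, compound 2 `COC(=O)C1=C(C)NC(C)=C(C(=O)OCCCl)C1c1cccc([N+](=O)[O-])c1` gives 22 nM, and compound 3 `COC(=O)C1=C(C)NC(C)=C(C(=O)OCc2ccc(F)c(F)c2)C1c1cccc([N+](=O)[O-])c1` gives 20 nM. Compound 3 holds the lowest of the three numbers, though its steps to the other two lie within the scatter. Compound 4 `COC(=O)C1=C(C)NC(C)=C(C(=O)OCCOCc2ccccc2)C1c1cccc([N+](=O)[O-])c1` carries the change ((benzyloxy)methyl in place of 3,4-difluorophenyl on a saturated chain carbon bound to an oxygen next to a carbonyl group). The steps bearing on it, a 1.0-fold higher number from compound 1 to compound 2 (0.02 log units; within the scatter), a 1.1-fold lower number from compound 1 to compound 3 (0.02 log units; within the scatter) and a 1.1-fold lower number from compound 2 to compound 3 (0.04 log units; within the scatter), show that three quite different groups at this place left the value essentially unchanged, so no step beyond the scatter is expected for compound 4. The expected value for compound 4 is 21 nM, between 10 nM and 45 nM, meaning a 1.1-fold higher number from compound 3 to compound 4 (0.02 log units; within the scatter).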

Compound 4, half-maximal inhibitory concentration: 12 nM
For compound 4 the middle estimate is 1.8-fold (0.24 log units) above the measured one; low and high end bracket the measured number.
By their numbers in this assay, from the lowest: compounds 4, 3, 1 and 2 (each within the scatter of the next).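

The 2-(benzyloxy)ethyl tail brings an oxygen into the chain, which none of the earlier tails had, yet in this assay it stays within the scatter of all three earlier compounds (a 1.7-fold lower number from compound 3 to compound 4 (0.22 log units; within the scatter) and a 1.8-fold lower number from compound 2 to compound 4 (0.26 log units; within the scatter) and a 1.8-fold lower number from compound 1 to compound 4 (0.24 log units; within the scatter)). This place on the ester has now taken four quite different groups with no step beyond the scatter. No measurement shown explains this tolerance.

On these data alone, whether the same holds for a tail ending in an amine or a carboxylic acid remains open. A longer chain is equally untested among the compounds shown.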